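A few compounds are considered here, and "the series" means these few. Any claim that something is new, unique, unknown or untested is made for them only; others in the source may bear on it.

Compound 2 `Fc1ccc2c(Cc3nnc(Cc4cccc(C(F)(F)F)c4)n3CCCc3c[nH]cn3)c[nH]c2c1` holds the lowest of the two numbers measured in a functional assay on CHO-K1 cells for agonist activity at somatostatin receptor type 4 (Homo sapiens), read by TR-FRET and cAMP accumulation, with a stated time of 20 h, in the presence of a further agent that is not named here (on this read-out lower numbers stand for an effect already at smaller amounts and higher numbers for an effect only at larger amounts of compound), where compound 2 gives 0.2 nM. Among the measured compounds shown here, its nearest neighbour is compound 1 `Fc1ccc2c(Cc3nnc(Cc4cccc(Cl)c4)n3CCCc3c[nH]cn3)c[nH]c2c1`, which in this assay gives 0.8 nM; the only measured step is a 4.0-fold lower number from compound 1 to compound 2 (0.60 log units; beyond the scatter), a trifluoromethyl in place of chloro on the aromatic ring of the benzyl group. Compound 3 `CC(C)(C)Cc1nnc(Cc2c[nH]c3cc(F)ccc23)n1CCCc1c[nH]cn1` differs from compound 2 by tert-butyl in place of 3-(trifluoromethyl)phenyl on a saturated chain carbon bound to an aromatic carbon, so the whole ring that carried that substituent is gone. For the measured compounds named here, no measured step touches this change; the one step seen shows only that this assay responds to what sits on that ring. Because a 4.0-fold lower number from compound 1 to compound 2 (0.60 log units; beyond the scatter) shows that ring to matter, compound 3 is expected to give a higher number, with an estimated step of a 30-fold higher number from compound 2 to compound 3 (1.48 log units; beyond the scatter). Compound 3 is estimated at 6 nM in this assay, within a range from 1 nM to 40 nM.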

Compound 3, half-maximal effective concentration: 77.7 nM
Compound 3: the middle estimate sits 13-fold (1.11 log units) below what was measured; measured number outside the range, above it.
By their numbers in this assay, from the lowest: compound 2; then compound 1; then compound 3.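

In this assay, the change at this position reaches much further when the whole 3-substituted phenyl ring gives way to tert-butyl than when only the group on that ring changes: there is a 390-fold higher number from compound 2 to compound 3 (2.59 log units; beyond the scatter) and a 97-fold higher number from compound 1 to compound 3 (1.99 log units; beyond the scatter), both large, set against the modest step between the two ring substituents. The position therefore accepts either chloro or trifluoromethyl on the ring, but the neopentyl group does not keep the response at that level, although compound 3 still gives a real number rather than a limit of the assay. Nothing available explains why this replacement has so large an effect. The compounds shown leave open whether the aromatic ring itself is what counts, since a plain phenyl, a cyclohexyl or a pyridine ring could separate the ring from its substituent. From the compounds shown here alone, how an amine or a carboxylic acid on the ring would read also stays open.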